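Replacing 3-fluorobenzyl with ethyl on the shared core

The compounds below may be only part of what the source reports. "The series", "measured", "known", "first", "only" and "open" are said of these compounds alone.

In a functional assay on J774.A1 cells (Mus musculus) for inhibition, read by Griess assay, with stated times of 1 h and 24 h (a higher number here means a weaker inhibitor, a lower number a stronger inhibitor), compound 3 (`O=C1CC(c2ccccc2OCc2cccc(F)c2)Oc2ccccc21`) gives 13200 nM. Compound 1 (`O=C1CC(c2ccccc2OCc2ccc(F)cc2)Oc2ccccc21`) gives 25500 nM, and the comparison shows a 1.9-fold lower number from compound 1 to compound 3 (0.29 log units; within the scatter). Compound 2 (`O=C1CC(c2ccccc2O)Oc2ccccc21`), with hydrogen on the oxygen, gives 71300 nM, and the comparison with the fluorobenzyl analogue shows a 5.4-fold lower number from compound 2 to compound 3 (0.73 log units; beyond the scatter).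

Compound 4 (`CCOc1ccccc1C1CC(=O)c2ccccc2O1`) differs from compound 3 by methyl in place of 3-fluorophenyl on a saturated chain carbon bound to an oxygen on an aromatic ring, or 3-fluorobenzyl to ethyl. Among the compounds with values here, no measured compound carries a small chain at that oxygen. The closest guides are the two steps that exchange the whole group for hydrogen, a 2.8-fold higher number from compound 1 to compound 2 (0.45 log units; beyond the scatter) and a 5.4-fold lower number from compound 2 to compound 3 (0.73 log units; beyond the scatter). Ethyl keeps a chain but loses the ring, so a position between these measured extremes seems likely. The expected result is a 2.7-fold higher number from compound 3 to compound 4 (0.42 log units; beyond the scatter), a modest move towards a higher number. For compound 4 the estimate is 35000 nM, with an expected range from 15000 nM to 75000 nM.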

Compound 4, half-maximal inhibitory concentration: 38800 nM
For compound 4 the middle estimate is 1.1-fold (0.04 log units) below the measured one; the measured number falls inside the stated range.
By their numbers in this assay, from the lowest: compounds 3, 1, 4 and 2 (each within the scatter of the next, the first and the last beyond it).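

In this assay, the change from 3-fluorobenzyl to ethyl on the oxygen gives a 2.9-fold higher number from compound 3 to compound 4 (0.47 log units; beyond the scatter), so at this position a small chain does not match compound 3. The ethyl compound cannot be separated from either hydrogen, with a 1.8-fold lower number from compound 2 to compound 4 (0.26 log units; within the scatter), or 4-fluorobenzyl, with a 1.5-fold higher number from compound 1 to compound 4 (0.18 log units; within the scatter), although those two groups are separated from each other by a step beyond the scatter. No supporting data explain these differences.

As far as these compounds go, it remains open whether a longer chain, such as butyl, or a chain ending in an amine on this oxygen would stand closer to compound 3 or to compound 4. Unsubstituted benzyl would be needed to show how much of the step from compound 3 to compound 4 goes with the fluorine and how much with the ring.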